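From 4-fluorobenzyl to 3-methoxybenzyl at the assay limit

A few compounds are considered here, and "the series" means these few. Any claim that something is new, unique, unknown or untested is made for them only; others in the source may bear on it.

Measured in an ADME assay on HepG2 cells (Homo sapiens) for cytotoxicity, read by MTT assay, with a stated time of 48 h (a higher number here means a weaker inhibitor, a lower number a stronger inhibitor), each value a limit:
compound 1 `O=S(=O)(c1ccc(-c2ccc3ncnc(Nc4ccc(OCc5cccc(Cl)c5)c(Cl)c4)c3c2)cc1)N1CCOCC1`: > 15000 nM
compound 2 `O=S(=O)(c1ccc(-c2ccc3ncnc(Nc4ccc(OCc5ccccc5F)c(Cl)c4)c3c2)cc1)N1CCOCC1`: > 15000 nM
compound 3 `O=S(=O)(c1ccc(-c2ccc3ncnc(Nc4ccc(OCc5ccc(F)cc5)c(Cl)c4)c3c2)cc1)N1CCOCC1`: > 15000 nM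

Compound 3 gives only a limit, > 15000 nM. The measured compounds share one reading: the limit of > 15000 nM in this assay, at which 3 of the 3 values shown sit.

Compound 4 `COc1cccc(COc2ccc(Nc3ncnc4ccc(-c5ccc(S(=O)(=O)N6CCOCC6)cc5)cc34)cc2Cl)c1` carries 3-methoxyphenyl in place of 4-fluorophenyl on a saturated chain carbon bound to an oxygen on an aromatic ring. The closest evidence lies in two exchanges at that same place: a step that the two limits leave unreadable from compound 1 to compound 3 and a step that the two limits leave unreadable from compound 2 to compound 3. Within the data shown here, neither has a readable size, so no known step can be carried over in this assay, and no change beyond the scatter is expected in either direction. The expected move is a step that the limit leaves unreadable from compound 3 to compound 4. For compound 4 the estimate is 20000 nM, with an expected range of 10000 nM to 40000 nM.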

Compound 4, half-maximal inhibitory concentration: > 15000 nM
Compound 4: only a limit was reported (the forecaster's own chance of this, stated with the estimate: 85%); the middle value is on the limit's open side.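

Compound 1, compound 2, compound 3 and compound 4 all give only a limit in this assay, so no step among them can be read: the limit of > 15000 nM in this assay, at which 4 of the 4 values shown sit.

The compounds shown leave open how far each lies past that limit, and whether exchanging these groups changes the read-out at all.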